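This account rests on a few compounds, and the source may have more. Where it says the series, first, only, none or still open, it means among the compounds named here.

Measured so far:

Compound 1, `CCCCCCCCCCCCNC(=O)[C@@H](NS(=O)(=O)c1ccc(C)cc1)[C@@H](C)O` — in a functional assay on SiHa cells (Homo sapiens) for cytotoxicity, read by MTT assay, with a stated time of 48 h (on this read-out lower numbers stand for stronger inhibition and higher numbers for weaker inhibition), compound 1 gives 31600 nM.
Compound 2, `CCCCCCCCCCCCNC(=O)[C@@H](NS(=O)(=O)c1cccs1)[C@@H](C)O` — compound 2 gives 30900 nM.
Compound 3, `CCCCCCCCCCCCCCCCCCNC(=O)[C@@H](NS(=O)(=O)c1ccc(C)cc1)[C@@H](C)O` — compound 3 gives 29800 nM.

All three share a core; compound 3 differs from compound 1 only in the chain, a difference counted as hexyl in place of hydrogen on a saturated chain carbon, ten or more bonds along the chain from an amide-type nitrogen. That change made a step of a 1.1-fold lower number from compound 1 to compound 3 (0.03 log units; within the scatter), so the two chain lengths cannot be told apart on this read-out.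

Compound 4, `CCCCCCCCCCCCCCCCCCNC(=O)[C@@H](NS(=O)(=O)c1cccs1)[C@@H](C)O`, has not yet been measured. It carries the longer chain of compound 3 and differs from it in one place: thiophen-2-yl in place of 4-methylphenyl on a sulfonyl sulfur. The same change, at the same place, has already been made once among the measured compounds, going from compound 1 to compound 2: thiophen-2-yl in place of 4-methylphenyl on a sulfonyl sulfur. There it produced a step of a 1.0-fold lower number from compound 1 to compound 2 (0.01 log units; within the scatter), which is to say no change at all that the assay could resolve.

On that single precedent, compound 4 is expected to sit close to compound 3, with a step of about a 1.0-fold lower number from compound 3 to compound 4 (0.01 log units; within the scatter) in this assay, because the same change gave a 1.0-fold lower number from compound 1 to compound 2 (0.01 log units; within the scatter) on the shorter chain. Compound 4 is therefore estimated at 29000 nM, most likely between 15000 nM and 58000 nM.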

Compound 4, half-maximal inhibitory concentration: > 200000 nM
Compound 4 gave a limit, no number; the forecaster's own chance of this, stated with the estimate: 5%; middle value at least 6.8-fold (0.83 log units) from the limit.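

In this assay compound 4 gives > 200000 nM, which is a limit of the assay and not a number, so the true size of its steps and the reason for them remain unknown. On the longer chain, the change from 4-methylphenyl to thiophen-2-yl gave an at least 6.7-fold higher number from compound 3 to compound 4 (0.82 log units; beyond the scatter), so the near-absence of any effect on the shorter chain did not carry over, and the two results differ: the same change on two cores in this assay, a 1.0-fold lower number (0.01 log units; within the scatter) from compound 1 to compound 2 and an at least 6.7-fold higher number (0.82 log units; beyond the scatter) from compound 3 to compound 4, at least 6.8-fold (0.83 log units) apart, beyond the scatter of two such steps Seen from the other direction, the longer chain has no resolvable effect with 4-methylphenyl but gives an at least 6.4-fold higher number from compound 2 to compound 4 (0.81 log units; beyond the scatter) with thiophen-2-yl, so the effect of each change depends on the other part of the molecule, at least in this single set of four compounds: the same change on two cores in this assay, a 1.1-fold lower number (0.03 log units; within the scatter) from compound 1 to compound 3 and an at least 6.4-fold higher number (0.81 log units; beyond the scatter) from compound 2 to compound 4, at least 6.8-fold (0.83 log units) apart, beyond the scatter of two such steps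

Going by these compounds, whether an unsubstituted phenyl or a furan-2-yl group on the sulfonyl sulfur would follow 4-methylphenyl or thiophen-2-yl on the longer chain remains open. Among these compounds, also open is the chain length at which the thiophen-2-yl compounds begin to differ, since only two lengths appear here.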